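Fluoro for Methyl in a Cytotoxicity Series

This account rests on a few compounds, and the source may have more. Where it says the series, first, only, none or still open, it means among the compounds named here.

Three compounds share a sulfonamide-bearing core. Compound 1 `NS(=O)(=O)c1ccc(N2N=C(c3ccccc3)CC2c2ccccc2F)cc1` was tested in an ADME assay on BHK-21 cells (Mesocricetus auratus) for cytotoxicity, read by MTT assay, with a stated time of 72 h (a lower number here means that less compound is tolerated, a higher number that more compound is tolerated), and gives 21000 nM. Compound 3 `Cc1ccccc1C1CC(c2ccccc2)=NN1c1ccc(S(N)(=O)=O)cc1` gives 14000 nM in this assay, and compound 2 `Cc1ccccc1C1CC(c2ccc(Oc3ccccc3)cc2)=NN1c1ccc(S(N)(=O)=O)cc1` gives 7000 nM.

Compound 3 and compound 1 differ by the change (fluoro in place of methyl on an aromatic carbon); this produced a 1.5-fold higher number from compound 3 to compound 1 (0.18 log units; within the scatter). Compound 3 and compound 2 differ in their cores by phenoxy in place of hydrogen on an aromatic carbon, and this step shows a 2.0-fold higher number from compound 2 to compound 3 (0.30 log units; within the scatter). Compound 2 and compound 1 are not compared as a single step; their two values simply sit apart as shown.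

Compound 4 `NS(=O)(=O)c1ccc(N2N=C(c3ccc(Oc4ccccc4)cc3)CC2c2ccccc2F)cc1` has not yet been measured. Going by the values given here, it differs from compound 2 by fluoro in place of methyl on an aromatic carbon, which is the same change as the one from compound 3 to compound 1, made on the core of compound 2 rather than that of compound 3. Because the earlier step gave a 1.5-fold higher number from compound 3 to compound 1 (0.18 log units; within the scatter), a step of a 1.4-fold higher number from compound 2 to compound 4 (0.15 log units; within the scatter) is expected here. On that basis compound 4 is estimated at 10000 nM, within a range from 5000 nM to 21000 nM.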

Compound 4, half-maximal cytotoxic concentration: 32000 nM
The estimate for compound 4 lay 3.2-fold (0.51 log units) below the measured number; measured number outside the range, above it.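

In this assay, fluoro in place of methyl gave a 4.6-fold higher number from compound 2 to compound 4 (0.66 log units; beyond the scatter) on the core carrying phenoxy, and this step did not match the one on the core without phenoxy: the same change on two cores in this assay, a 1.5-fold higher number (0.18 log units; within the scatter) from compound 3 to compound 1 and a 4.6-fold higher number (0.66 log units; beyond the scatter) from compound 2 to compound 4, 3.0-fold (0.48 log units) apart, beyond the scatter of two such steps Read from the other side of the same four compounds, phenoxy in place of hydrogen gave a 1.5-fold higher number from compound 1 to compound 4 (0.18 log units; within the scatter), and this change likewise did not carry over unaltered from one core to the other: the same change on two cores in this assay, a 2.0-fold higher number (0.30 log units; within the scatter) from compound 2 to compound 3 and a 1.5-fold lower number (0.18 log units; within the scatter) from compound 4 to compound 1, 3.0-fold (0.48 log units) apart, beyond the scatter of two such steps With a single pair on each core, this shows that neither step can be moved between these two cores at a fixed size, but it does not show why, nor how either step would read on any other core.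

The compounds shown leave open whether a chloro or methoxy group in place of the fluoro would follow compound 4 or compound 1. They also leave open how an amine or a carboxylic acid in place of the phenoxy would behave on either core.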